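The source may report more compounds than this note shows. Statements on the series, on what has been measured and on what is new or still open speak of the compounds shown alone.

In a functional assay on PC-12 cells (Rattus norvegicus) for cytotoxicity, read by MTT assay, with stated times of 3 h and 2 h, tested at 50 uM (on this read-out lower numbers stand for a weaker effect and higher numbers for a stronger effect at the one concentration tested), compound 1 `O=C(CCCCC1CCSS1)NCc1cn(CCCOc2ccc3ccc(=O)oc3c2)nn1` gives 43.5%. Compound 2 `CCOC(=O)c1cc2ccc(OCCCn3cc(CNC(=O)CCCCC4CCSS4)nn3)cc2oc1=O` gives 49.2%, and compound 3 `O=C(CCCCC1CCSS1)NCc1cn(CCCOc2ccc3cc(-c4ccccc4)c(=O)oc3c2)nn1` gives 23.1%. Among these three numbers compound 1 stands second highest; the step of a number 5.7 percentage points higher from compound 1 to compound 2 (within the scatter) lies within the scatter, while the step of a number 20.4 percentage points lower from compound 1 to compound 3 (beyond the scatter) lies beyond it. Compound 4 `COc1ccc(-c2cc3ccc(OCCCn4cc(CNC(=O)CCCCC5CCSS5)nn4)cc3oc2=O)cc1` has not yet been measured in this assay; it differs from compound 1 by 4-methoxyphenyl in place of hydrogen on an aromatic carbon. The step that bears most directly on this change is a number 20.4 percentage points lower from compound 1 to compound 3 (beyond the scatter), phenyl in place of hydrogen on an aromatic carbon; a second view of the same kind of change, a number 26.1 percentage points lower from compound 2 to compound 3 (beyond the scatter), points the same way. A 4-methoxyphenyl is not identical to a bare phenyl, so the exact size is uncertain, but a modest drop beyond the scatter is expected for compound 4, namely a number 18.5 percentage points lower from compound 1 to compound 4 (beyond the scatter). Compound 4 is therefore expected to give about 25%, with a range from 12% to 40%.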

Compound 4, a percentage reported as activity, at one concentration (the size of the read-out at that concentration, not a potency): 65.7%
The estimate for compound 4 lay 40.7 percentage points below the measured number; measured number above the stated range.
By their numbers in this assay, from the lowest: compound 3; then compounds 1 and 2 (each within the scatter of the next); then compound 4.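

In this assay, an added aromatic ring at this position does not always lower the number: phenyl did so in compound 3, but 4-methoxyphenyl gives a number 22.2 percentage points higher from compound 1 to compound 4 (beyond the scatter) and also stands clear of the ethoxycarbonyl group, with a number 16.5 percentage points higher from compound 2 to compound 4 (beyond the scatter). The single methoxy on the added ring reverses the direction, with a number 42.6 percentage points higher from compound 3 to compound 4 (beyond the scatter), so the outcome here depends on what that ring carries and not only on the ring being present. Nothing available explains this reversal.

As far as these compounds go, it remains open whether the methoxy oxygen itself matters or whether another small group on that ring, such as a hydroxyl, a chlorine or a methyl, would give the same rise. From the compounds shown here alone, a carboxylic acid or an amine at this position of the core also remains untested here.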